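Semicarbazones on a Naphthyl Urea: Toward a Hydroxyphenyl Variant

A few compounds are considered here, and "the series" means these few. Any claim that something is new, unique, unknown or untested is made for them only; others in the source may bear on it.

compound 1 `O=C(N/N=C/c1ccc(Cl)cc1Cl)Nc1cccc2ccccc12` — 300 mg/kg
compound 2 `O=C(N/N=C/c1ccccc1[N+](=O)[O-])Nc1cccc2ccccc12` — 300 mg/kg
compound 3 `O=C(N/N=C/c1ccc(Cl)cc1)Nc1cccc2ccccc12` — 300 mg/kg

The three measured compounds share one core and differ only in the aryl group on a carbon with a double bond to nitrogen. In a functional assay on the whole organism (strain Swiss albino) with Mus musculus as the target, with a stated time of 0.5 h (a higher number here means that more compound is needed for the effect, a lower number that less compound is needed), compound 3 gives 300 mg/kg, level with compound 1 and compound 2 within the scatter. Among the compounds with values here, the single measured step, no change at the digits printed from compound 1 to compound 3 (within the scatter), shows no change beyond the scatter. Compound 4 `O=C(N/N=C/c1ccccc1O)Nc1cccc2ccccc12` carries 2-hydroxyphenyl in place of 4-chlorophenyl on a carbon with a double bond to nitrogen. Within the data shown here, no measured step exchanges the aryl group for a hydroxyphenyl, so only the uniform readings so far bear on it. The expected step is no change at the digits printed from compound 3 to compound 4 (within the scatter), none beyond the scatter. Compound 4 is estimated at 300 mg/kg, between 150 mg/kg and 600 mg/kg.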

Compound 4, minimum effective dose: 300 mg/kg
The estimate for compound 4 equals the measured number at the digits printed; the measured number falls inside the stated range.
By their numbers in this assay, from the lowest: compounds 1, 2, 3 and 4 (each within the scatter of the next).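

Exchanging 4-chlorophenyl for 2-hydroxyphenyl on a carbon with a double bond to nitrogen adds a hydrogen-bond donor and a hydrogen-bond acceptor, yet in this assay the result is no change at the digits printed from compound 3 to compound 4 (within the scatter) at this position. The hydroxy group also matches the other aryl substituents, with no change at the digits printed from compound 2 to compound 4 (within the scatter) for the nitro exchange and no change at the digits printed from compound 1 to compound 4 (within the scatter) for the 2,4-dichlorophenyl exchange, so the four compounds stand level. Nothing available accounts for this flat reading.

As far as these compounds go, it remains open whether an amine or a carboxylic acid on the aryl ring, or a longer alkyl chain in place of it, would shift the minimum effective dose. From the compounds shown here alone, the effect of changes to the shared core also remains open.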